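The compounds below may be only part of what the source reports. "The series", "measured", "known", "first", "only" and "open" are said of these compounds alone.

Measured in a functional assay on the whole organism with Mus musculus as the target, in the rotarod test; a higher number here means that more compound is needed for the effect, a lower number that less compound is needed:
- Compound 1 `CC(=O)NCC(=O)Nc1ccc(Cl)cc1C(=O)c1ccccc1`: > 100 mg/kg, a limit
- Compound 2 `CN(C(=O)CNC(=O)CN)c1ccc([N+](=O)[O-])cc1C(=O)c1ccccc1Cl`: 10 mg/kg
- Compound 3 `CC(C)NCC(=O)NCC(=O)N(C)c1ccc(Cl)cc1C(=O)c1ccccc1Cl`: 13 mg/kg

Compound 2 gives 10 mg/kg and compound 3 gives 13 mg/kg, so the two values lie within the scatter of each other. For compound 1, this assay reports only a limit, > 100 mg/kg.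

Compound 4 `NCC(=O)NCC(=O)Nc1ccc([N+](=O)[O-])cc1C(=O)c1ccccc1Cl` has not yet been measured. It differs from compound 2 as follows: hydrogen in place of methyl on an amide-type nitrogen. In words, hydrogen stands in place of methyl on an amide-type nitrogen.

Among the compounds with values here, no measured pair isolates this change. Compound 1 also has hydrogen on an amide-type nitrogen, but it differs from compound 2 in other places too, so it offers only a weak hint. On that hint, a higher number is expected, with a step somewhat beyond the scatter. The expected step is a 3.0-fold higher number from compound 2 to compound 4 (0.48 log units; beyond the scatter). The estimate for compound 4 is 30 mg/kg, with an expected range of 8 mg/kg to 120 mg/kg.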

Compound 4, dose for half-maximal effect: 63.9 mg/kg
Compound 4: middle estimate off by 2.1-fold (0.33 log units), on the low side; measured number inside the range.
By their numbers in this assay, from the lowest: compounds 2 and 3 (each within the scatter of the next); then compound 4. At a limit, above all of these: compound 1.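

Setting hydrogen in place of methyl on the amide-type nitrogen, whose other neighbours are an aromatic carbon and a carbonyl carbon, gives the first clean reading of this position in this assay: a 6.4-fold higher number from compound 2 to compound 4 (0.81 log units; beyond the scatter). The step lies beyond the scatter, so in this pair the methyl on this nitrogen goes with a lower number, and less compound is needed for the effect. The value of compound 1 is only a limit and could not show this: the limit of > 100 mg/kg in this assay, at which 1 of the 4 values shown sits.

The compounds shown leave open what an ethyl group or a longer chain on this nitrogen would do to the number. They also leave open whether the same exchange of methyl for hydrogen would give a similar step when made on compound 3.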